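From fluoro to nitro in a small cytotoxic series

The source may hold more compounds than are shown below. What is called first, only, known or untested is meant among the compounds shown, and "the series" means these compounds.

Within the data shown here, in a functional assay on NCI-H460 cells (Homo sapiens) for cytotoxicity, read by sulforhodamine B assay, with a stated time of 3 days (on this read-out lower numbers stand for stronger inhibition and higher numbers for weaker inhibition), three related compounds have numbers so far. Compound 2 (`OCc1cn(Cc2cccc(F)c2)c2ccccc12`) gives 40 nM there and compound 3 (`OCc1cn(Cc2ccc(Br)cc2)c2ccccc12`) gives 31 nM there, two numbers that lie within the usual scatter of repeated measurements. Compound 1 (`O=Cc1cn(Cc2ccc(Cl)cc2)c2ccc(Cl)cc12`) gives 400 nM there, a higher number that means weaker inhibition and lies well beyond that scatter. Compound 2 therefore sits close to compound 3 and far from compound 1.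

Compound 4 (`O=[N+]([O-])c1cccc(Cn2cc(CO)c3ccccc32)c1`) has no number yet. It matches compound 2 except at one place, with nitro in place of fluoro on an aromatic carbon of a six-membered aromatic ring of carbon only, meta to a large group.

Among the measured compounds shown here, no pair of measured compounds shows this swap, so any expectation is rough. For the measured compounds named here, the only guide is compound 3, which carries a different halogen on that ring and gives 31 nM in a range that cannot be told apart from compound 2. In this assay a step no larger than the scatter is therefore expected, with no clear direction. The estimated step is a 1.1-fold higher number from compound 2 to compound 4 (0.05 log units; within the scatter) and it fits that expectation. For compound 4 the estimated value is 45 nM with an expected range of 15 nM to 150 nM in this estimate.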

Compound 4, half-maximal inhibitory concentration: 39 nM
Estimate against measurement, compound 4: 1.2-fold (0.06 log units) above; low and high end bracket the measured number.
By their numbers in this assay, from the lowest: compounds 3, 4 and 2 (each within the scatter of the next); then compound 1.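

In this assay, the first direct test of this swap, nitro in place of fluoro gives a 1.0-fold lower number from compound 2 to compound 4 (0.01 log units; within the scatter), so the two compounds cannot be told apart. This place, on an aromatic carbon of a six-membered aromatic ring of carbon only, meta to a large group, therefore accepts nitro, with 3 heavy atoms and 2 hydrogen-bond acceptors, in place of fluoro, with 1 heavy atom and 0 hydrogen-bond acceptors, without a change beyond the scatter, although this rests on a single pair of compounds. Nothing measured here accounts for why the number holds across this swap.

From the compounds shown here alone, it remains open whether the same place would also tolerate an amine, a carboxylic acid or a longer chain such as a butyl group, any of which could show where this tolerance ends. Compound 1 differs from compound 2 and compound 4 in more than one place, so the compounds shown cannot tie its number to any single change, and the role of the hydroxymethyl group on the shared core also stays unresolved.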